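The compounds below may be only part of what the source reports. "The series", "measured", "known", "first", "only" and "open" are said of these compounds alone.

Measured compounds:
compound 1 `COc1ccc(C2C(C(=O)/C=C/c3ccccc3)=C(/C=C/c3ccccc3)N=C3SC=C(C)N32)cc1` gives 211 ug/mL
compound 2 `COc1ccc(C2C(C(=O)/C=C/c3ccc(Cl)cc3)=C(/C=C/c3ccc(Cl)cc3)N=C3SC=C(C)N32)cc1` gives 273 ug/mL
compound 3 `CC1=CSC2=NC(/C=C/c3ccccc3)=C(C(=O)/C=C/c3ccccc3)C(c3ccc(Cl)cc3)N12` gives 320 ug/mL

All three numbers come from an ADME assay on Vero cells (Chlorocebus sabaeus) for cytotoxicity, read by fluorescence and resazurin assay, with a stated time of 72 h; a lower number here means that less compound is tolerated, a higher number that more compound is tolerated. Compound 1 and compound 3 share one core and differ in a single place, the change being (chloro in place of methoxy on an aromatic carbon). That change gave a 1.5-fold higher number from compound 1 to compound 3 (0.18 log units; within the scatter), so the two values are not separable by this assay. Compound 2 is built on a different core, and the difference between the two cores is not broken down here; its value in this assay sits close to those of compound 1 and compound 3, and none of the three pairs can be ordered.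

Compound 4 `CC1=CSC2=NC(/C=C/c3ccc(Cl)cc3)=C(C(=O)/C=C/c3ccc(Cl)cc3)C(c3ccc(Cl)cc3)N12` has not been measured in this assay. Relative to compound 2 it carries the change (chloro in place of methoxy on an aromatic carbon), which is the same change as that from compound 1 to compound 3, made at a place described in identical words. Going by the values given here, the only guide for the expected step from compound 2 to compound 4 is therefore the measured step from compound 1 to compound 3, which was small. Since compound 1 to compound 3 gave a 1.5-fold higher number from compound 1 to compound 3 (0.18 log units; within the scatter), the step for compound 4 is expected to be of the same small size, a 1.2-fold higher number from compound 2 to compound 4 (0.10 log units; within the scatter), and the estimate for compound 4 in this assay is 340 ug/mL, with a range from 200 ug/mL to 580 ug/mL. Whether this holds on the second core remains to be seen once compound 4 is measured.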

Compound 4, half-maximal cytotoxic concentration: 309 ug/mL
The estimate for compound 4 lay 1.1-fold (0.04 log units) above the measured number; measured number inside the range.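

Replacing methoxy with chloro on an aromatic carbon, the change from 4-methoxyphenyl to 4-chlorophenyl, gives a 1.1-fold higher number from compound 2 to compound 4 (0.05 log units; within the scatter) in this assay, so on the core of compound 2 this assay cannot separate the two compounds. Set beside the earlier step, the result on this core agrees with that on the core of compound 1, and the change reads as small on both: the same change on two cores in this assay, a 1.5-fold higher number (0.18 log units; within the scatter) from compound 1 to compound 3 and a 1.1-fold higher number (0.05 log units; within the scatter) from compound 2 to compound 4, 1.3-fold (0.13 log units) apart, within the scatter of two such steps. This shows that, in these two matched pairs, the change produced no step that this assay can resolve, but it does not establish a shared shift of any fixed size, since both steps lie within the scatter, and it gives no reason for the agreement and no basis for extending it to any other core.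

The compounds shown leave open whether a group of a different kind at the same place, such as an amine, a carboxylic acid or a longer alkyl chain, would produce a step that this assay can resolve. Going by these compounds alone, they also leave open whether such a step would have the same size on both cores, as the only comparison available here is between methoxy and chloro.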